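The source may hold more compounds than are shown below. What is called first, only, known or untested is meant among the compounds shown, and "the series" means these compounds.

The measured compounds and their values:

- Compound 1, `O=C(Cn1c(=O)oc2cc(Cl)ccc21)NCc1cccs1`, in an ADME assay on RAW264.7 cells (Mus musculus) for cytotoxicity, read by MTT assay, with a stated time of 72 h, tested at 50 uM (on this read-out higher numbers stand for a stronger effect at the one concentration tested and lower numbers for a weaker effect), gives 20.3%.
- Compound 2, `O=C(Cn1c(=O)oc2cc(Cl)ccc21)Nc1ccccc1`, in this assay gives 15.8%.

Among the compounds with values here, compound 2 stands next to compound 1, the only other measured compound, and the two numbers lie within the scatter of each other: the step of a number 4.5 percentage points lower from compound 1 to compound 2 (within the scatter) shows how small that gap is. The two compounds share a core and differ only in the group on the amide-type nitrogen.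

Compound 3, `O=C(Cn1c(=O)oc2cc(Cl)ccc21)NCc1ccco1`, has not yet been measured. It differs from compound 2 as follows: (furan-2-yl)methyl in place of phenyl on an amide-type nitrogen. Within the data shown here, the one measured step that bears on this change is a number 4.5 percentage points lower from compound 1 to compound 2 (within the scatter), where a ring-methyl group on that nitrogen was swapped for a plain phenyl ring and the number barely moved. Going back from phenyl to a ring-methyl group of similar size is therefore expected to shift the number little, in either direction, if at all beyond the scatter. The expected step is a number 3.2 percentage points higher from compound 2 to compound 3 (within the scatter). On this basis compound 3 is estimated to give 19%, within the range 8% to 30%, in this assay.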

Compound 3, a percentage reported as inhibition, at one concentration (the size of the read-out at that concentration, not a potency): 27.8%
Estimate against measurement, compound 3: 8.8 percentage points below; measured number inside the range.
By their numbers in this assay, from the lowest: compounds 2, 1 and 3 (each within the scatter of the next, the first and the last beyond it).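

In this assay, within the data shown here, (furan-2-yl)methyl in place of phenyl on the amide-type nitrogen gives a number 12 percentage points higher from compound 2 to compound 3 (beyond the scatter) and is the first step at this position to clear the usual scatter, which shows that the group here can shift the read-out, if only modestly. Furan-2-yl in place of thiophen-2-yl on the saturated chain carbon gives a number 7.5 percentage points higher from compound 1 to compound 3 (within the scatter) and so cannot be told apart from no change, meaning the two ring-bearing chains cannot be ranked against each other; nor does a simple rule that such chains beat phenyl hold, as compound 1 and compound 2 also lie within the scatter of each other. No measurement is available that would explain the step seen with compound 3.

Still open, from the compounds shown here alone, is whether the step depends more on the furan ring or on the saturated chain carbon that joins it to the nitrogen, and a benzyl group, which keeps the phenyl ring and adds that chain carbon, would separate the two. The compounds shown also leave open what a longer chain between the ring and the nitrogen, or an amine or a carboxylic acid on the ring, would do to the read-out at this single concentration.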